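The compounds below may be only part of what the source reports. "The series", "measured", "known", "first", "only" and "open" are said of these compounds alone.

Measured in an ADME assay on the whole organism (Rattus norvegicus, strain Wistar Han) for pharmacokinetics; a lower number here means that a smaller share of the oral dose reaches the circulation, a higher number that a larger share of the oral dose reaches the circulation:
compound 1 `CCn1c(-c2cnc(C)nc2)nc2c(N[C@H]3CCN(C(=O)C4CCC4)C3)ncnc21`: 74%
compound 2 `CCn1c(-c2ccc(C(F)(F)F)nc2)nc2c(O[C@H]3CCN(C(=O)c4cocn4)C3)ncnc21`: 100%
compound 3 `CCn1c(-c2ccc(C(F)(F)F)nc2)nc2c(O[C@H]3CCN(C(=O)N4CC(OC)C4)C3)ncnc21`: 52%

Compound 1 holds the second highest of the three numbers in this assay; compound 3 lies lower and compound 2 lies higher, and both gaps are beyond the scatter.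

Compound 4 `CCn1c(-c2cnc(C)nc2)nc2c(N[C@H]3CCN(C(=O)C4CCOCC4)C3)ncnc21` differs from compound 1 in one place: oxan-4-yl in place of cyclobutyl on a carbonyl carbon. Going by the values given here, the only measured step that also exchanges the group on a carbonyl carbon is a number 48 percentage points lower from compound 2 to compound 3 (beyond the scatter). Among the compounds with values here, that step swaps two quite different groups on a core with another linker and another aryl group, so it is a loose guide at best; no measured pair exchanges cyclobutyl for oxan-4-yl, and nothing shows whether the amide-linked core of compound 1 reacts as sharply as the pair of compound 2 and compound 3. For compound 4 the step of a number 9 percentage points lower from compound 1 to compound 4 (within the scatter) is expected, a mild lowering that could still fall within the scatter. Compound 4 is therefore estimated at 65%, in a range from 40% to 90%.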

Compound 4, oral bioavailability: 18%
Compound 4: the middle estimate sits 47 percentage points above what was measured; the whole stated range lies above it.
By their numbers in this assay, from the lowest: compound 4; then compound 3; then compound 1; then compound 2.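

In this assay, the group on the carbonyl carbon matters on the core of compound 1 as well: oxan-4-yl in place of cyclobutyl gives a number 56 percentage points lower from compound 1 to compound 4 (beyond the scatter). Going by these compounds alone, the only earlier step at this place, a number 48 percentage points lower from compound 2 to compound 3 (beyond the scatter), came from a different core and a different pair of groups, so a large step on exchanging this group now appears on both cores, and it does so here between two saturated rings, with oxan-4-yl carrying 1 hydrogen-bond acceptor and cyclobutyl 0. Nothing measured here accounts for the size of this step.

Still open, on these data alone, is whether the ring oxygen or the larger ring goes with the step, which cyclohexyl on the same carbonyl carbon would help separate. Also open, as far as these compounds go, is whether the cyclobutyl to oxan-4-yl exchange gives a step of similar size on the core of compound 2.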